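The source may report more compounds than this note shows. Statements on the series, on what has been measured and on what is new or still open speak of the compounds shown alone.

Working notes on a small series run in an assay for inhibition of Type-2 angiotensin II receptor (Rattus norvegicus); a higher number here means a weaker inhibitor, a lower number a stronger inhibitor. Compound 1, `CCCCCN(CCCCC)C(=O)N1CCN(C(=O)N(c2ccccc2)c2ccccc2)C(C(=O)O)C1`, gives 1.7 nM. Compound 2, `CC1CN(C(=O)N(c2ccccc2)c2ccccc2)CCN1C(=O)N(c1ccccc1)c1ccccc1`, gives 15 nM. Compound 3, `CCCCCN(CCCCC)C(=O)N1CCN(C(=O)N(c2ccccc2)c2cccc(Cl)c2)[C@H](C(=O)O)C1`, gives 0.4 nM, the lowest of the three numbers; its gap to compound 1 and its larger gap to compound 2 both lie beyond the scatter. Compound 4, `CCCCCN(CCCCC)C(=O)N1CCN(C(=O)N(c2ccccc2)c2cccc(C)c2)[C@H](C(=O)O)C1`, is not yet measured. It differs from compound 3 by methyl in place of chloro on an aromatic carbon. Going by the values given here, no step between measured compounds covers this exchange, so the expectation rests on compound 3 alone. For compound 4 in this assay the expected step is a 1.5-fold higher number from compound 3 to compound 4 (0.18 log units; within the scatter), essentially none beyond the scatter. Compound 4 is estimated at 0.6 nM, with a range from 0.2 nM to 2 nM.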

Compound 4, half-maximal inhibitory concentration: 0.7 nM
The estimate for compound 4 lay 1.2-fold (0.07 log units) below the measured number; low and high end bracket the measured number.
By their numbers in this assay, from the lowest: compounds 3 and 4 (each within the scatter of the next); then compound 1; then compound 2.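

In this assay the change from 3-chlorophenyl to 3-methylphenyl gives a 1.8-fold higher number from compound 3 to compound 4 (0.24 log units; within the scatter), so chloro and methyl cannot be told apart at this place on the aromatic ring. Going by these compounds alone, no pair among the earlier compounds isolated this position, and this step is the only reading of it with the rest of the molecule held fixed. Nothing at hand bears on why the two groups read alike.

Open, as far as these compounds go, is whether methoxy, an amine or a carboxylic acid on this carbon would keep the number in this range. Also open, from the compounds shown here alone, is whether the same exchange reads alike on the other phenyl ring.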